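Aryl for Alkyl on the Side Chain of an Amide

The compounds below may be only part of what the source reports. "The series", "measured", "known", "first", "only" and "open" are said of these compounds alone.

The measured compounds:
compound 1 `CC(C)CCC(=O)N[C@@H](C(=O)N1CCC(c2ccc(Cl)cc2)CC1)C(C)C` gives 26 nM in an assay on THP-1 cells for displacement of a labelled ligand from C-C chemokine receptor type 1 (Homo sapiens); on this read-out lower numbers stand for stronger inhibition and higher numbers for weaker inhibition;
compound 2 `CC(C)[C@@H](NC(=O)CCc1ccc(F)cc1)C(=O)N1CCC(c2ccc(Cl)cc2)CC1` gives 70 nM;
compound 3 `CC(C)[C@@H](NC(=O)c1ccc(F)cc1)C(=O)N1CCC(c2ccc(Cl)cc2)CC1` gives 118 nM.

Compound 1 holds the lowest number of the three, and both of its steps to the others lie beyond the scatter: a 2.7-fold higher number from compound 1 to compound 2 (0.43 log units; beyond the scatter) and a 4.5-fold higher number from compound 1 to compound 3 (0.66 log units; beyond the scatter). Between compound 2 and compound 3 the step is a 1.7-fold higher number from compound 2 to compound 3 (0.23 log units; within the scatter), so these two cannot be told apart.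

Compound 4 `Cc1ccc(CCC(=O)N[C@@H](C(=O)N2CCC(c3ccc(Cl)cc3)CC2)C(C)C)cc1` has not yet been measured in this assay. It differs from compound 1 at the same place as compound 2 does: 4-methylphenyl in place of isopropyl on a saturated chain carbon, two bonds along the chain from a carbonyl carbon. The closest guide is therefore the step to compound 2, where a ring entered at that same position and the number rose by a 2.7-fold higher number from compound 1 to compound 2 (0.43 log units; beyond the scatter). The step to compound 3 points the same way, with a ring replacing a chain on the carbonyl carbon and the number rising by a 4.5-fold higher number from compound 1 to compound 3 (0.66 log units; beyond the scatter). Nothing here separates a methyl from a fluorine on the ring, so compound 4 is expected to land near compound 2, with a step of about a 2.5-fold higher number from compound 1 to compound 4 (0.40 log units; beyond the scatter). The estimate for compound 4 is 65 nM, with a range from 30 nM to 140 nM.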

Compound 4, half-maximal inhibitory concentration: 105 nM
Compound 4: the middle estimate sits 1.6-fold (0.21 log units) below what was measured; measured number inside the range.
By their numbers in this assay, from the lowest: compound 1; then compounds 2, 4 and 3 (each within the scatter of the next).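

Compound 2 is no longer the only case at this place: with 4-methylphenyl in place of isopropyl on the saturated chain carbon, there is a 4.0-fold higher number from compound 1 to compound 4 (0.61 log units; beyond the scatter) in this assay, so a second aromatic ring at this position also gives a step beyond the scatter. The group on that ring makes no readable difference in this pair, as methyl in place of fluoro gives a 1.5-fold higher number from compound 2 to compound 4 (0.18 log units; within the scatter), which is within the scatter. For the compounds shown here, the longer ring-bearing side chain also cannot be told apart from the 4-fluorophenyl group on the carbonyl carbon, since a 1.1-fold lower number from compound 3 to compound 4 (0.05 log units; within the scatter) is within the scatter too, leaving compound 1 and its all-carbon open chain as the only compound set apart from the others, with steps beyond the scatter to each of the three ring-bearing compounds.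

Nothing available here explains why these rings give higher numbers than the open chain.

Still open, as far as these compounds go, is how a cyclohexyl ring at the same place would compare with these aromatic rings, and how an amine or a carboxylic acid on the ring would read in this assay.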